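Swapping the Aromatic Group on a Thiourea

The source may report more compounds than this note shows. Statements on the series, on what has been measured and on what is new or still open speak of the compounds shown alone.

Values in a functional assay on U-373MG ATCC cells (Homo sapiens) for inhibition, read by MTT assay, with a stated time of 72 h; a higher number here means a weaker inhibitor, a lower number a stronger inhibitor:
- compound 1 `CC1(C)CC(NC(=S)Nc2ccc(C#N)cc2)c2cc(F)ccc2O1`: 11000 nM
- compound 2 `CC1(C)CC(NC(=S)Nc2ccc(C#N)cc2)c2cc(Cl)ccc2O1`: 10000 nM
- compound 3 `CC1(C)CC(NC(=S)Nc2ccc([N+](=O)[O-])cc2)c2cc(Cl)ccc2O1`: 3000 nM

Compound 2, at 10000 nM, has the second highest of the three numbers. Compound 4 `CC1(C)CC(NC(=S)NCc2ccccc2)c2cc(Cl)ccc2O1` differs from it by benzyl in place of 4-cyanophenyl on an amide-type nitrogen. Among the measured compounds shown here, only one measured swap touches the group that leaves, a 3.3-fold lower number from compound 2 to compound 3 (0.52 log units; beyond the scatter), and it keeps the aromatic ring directly on that nitrogen. The other, a 1.1-fold lower number from compound 1 to compound 2 (0.04 log units; within the scatter), lies elsewhere in the molecule. Neither shows what benzyl does, so no clear direction can be expected. The expected change is small, a 1.2-fold higher number from compound 2 to compound 4 (0.08 log units; within the scatter), with no shift beyond the scatter in this assay. For compound 4 the estimated value is 12000 nM, with an expected range of 4000 nM to 40000 nM.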

Compound 4, half-maximal inhibitory concentration: 64000 nM
Beside the measured number, compound 4's estimate is 5.3-fold (0.73 log units) below it; the whole stated range lies below it.
By their numbers in this assay, from the lowest: compound 3; then compounds 2 and 1 (each within the scatter of the next); then compound 4.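

Among the compounds shown here, on this amide-type nitrogen, the choice of group matters more than the earlier compounds showed: benzyl in place of 4-cyanophenyl gives a 6.4-fold higher number from compound 2 to compound 4 (0.81 log units; beyond the scatter), the largest step so far and one towards a weaker inhibitor. Unlike the earlier swap at this group, this change removes the nitrile and also no longer keeps the aromatic ring directly on the nitrogen. Nothing available explains this loss of activity. Which of the two differences matters stays open: a plain phenyl group or a 4-cyanobenzyl group on that nitrogen would separate them.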